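The compounds below may be only part of what the source reports. "The series", "measured", "known", "first", "only" and "open" are said of these compounds alone.

The three measured compounds share one core, and all were examined in an ADME assay on HEK293 cells (Homo sapiens) for cytotoxicity, read by MTT assay, with a stated time of 48 h; a lower number here means a stronger inhibitor, a higher number a weaker inhibitor. Compound 1 `CCS(=O)(=O)Nc1ccc(NC(=O)c2ccc(Cl)cc2)cc1C` gives 125000 nM in this assay. Compound 2 `Cc1cc(NC(=O)c2ccc(Cl)cc2)ccc1NS(=O)(=O)C(F)(F)F` gives 201000 nM in this assay, a change that amounts to a 1.6-fold higher number from compound 1 to compound 2 (0.21 log units; within the scatter). Compound 3 `Cc1cc(NC(=O)c2ccc(C#N)cc2)ccc1NS(=O)(=O)C(F)(F)F` yields in this assay only a limit of the assay, > 250000 nM, which is the limit of > 250000 nM in this assay, at which 1 of the 3 values shown sits. The move from chloro to cyano therefore shows up as an at least 1.2-fold higher number from compound 2 to compound 3 (0.09 log units; that floor lies within the scatter). Among the two actual numbers, compound 2 holds the higher one, with compound 1 the nearest, though the gap between them is within the scatter.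

Compound 4 `COc1cc(NC(=O)c2ccc(Cl)cc2)ccc1NS(=O)(=O)C(F)(F)F` has not yet been measured. It differs from compound 2 by methoxy in place of methyl on an aromatic carbon. Neither measured step touches this position: a 1.6-fold higher number from compound 1 to compound 2 (0.21 log units; within the scatter) altered the group on the sulfonyl sulfur, and an at least 1.2-fold higher number from compound 2 to compound 3 (0.09 log units; that floor lies within the scatter) altered the group on the other aromatic ring, and both stayed within the usual scatter. Going by the values given here, with no step on record that exceeds the scatter, the expectation for compound 4 in this assay is a step of a 1.0-fold lower number from compound 2 to compound 4 (0.00 log units; within the scatter), which means no change beyond the scatter. Compound 4 is therefore estimated to give 200000 nM in this assay, between 90000 nM and 300000 nM.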

Compound 4, half-maximal inhibitory concentration: > 250000 nM
Compound 4 was reported as a limit; the forecaster's own chance of this, stated with the estimate: 35%; at least 1.2-fold (0.09 log units) between middle value and limit.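

Going by these compounds alone, the earlier compounds changed only the group on the sulfonyl sulfur and the group on the other aromatic ring, so compound 4 is the first to show a change on the aromatic carbon ortho to the ((trifluoromethyl)sulfonyl)amino group, where methoxy brings in one hydrogen-bond acceptor that methyl lacks; in this assay this change gives an at least 1.2-fold higher number from compound 2 to compound 4 (0.09 log units; that floor lies within the scatter). Compound 4 gives > 250000 nM, which is a limit of the assay and not a number. The change at this position therefore brings no sign of stronger inhibition in the cells, though its floor cannot separate a real rise from no change, and it places compound 4 in the same position as compound 3 with respect to the assay's ceiling: the limit of > 250000 nM in this assay, at which 2 of the 4 values shown sit.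

As far as these compounds go, how far compound 3 and compound 4 actually lie past that limit stays unknown, so a size for the methoxy step cannot be given. From the compounds shown here alone, whether an amine, a hydroxyl or a longer chain such as ethoxy on this aromatic carbon would bring the number down into the measurable range also remains open.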